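Fluoro to Hydroxy: Estimating Growth Inhibition for Compound 3

This account rests on a few compounds, and the source may have more. Where it says the series, first, only, none or still open, it means among the compounds named here.

In a functional assay on 786-0 cells (Homo sapiens) for inhibition, read by sulforhodamine B assay, with a stated time of 48 h (a higher number here means a weaker inhibitor of growth, a lower number a stronger inhibitor of growth), compound 1 (`CC1(/C=C/c2ccc(C(F)(F)F)cc2)C=CC(=O)O1`) gives 34000 nM, and compound 2 (`CC1(/C=C/c2ccc(F)cc2)C=CC(=O)O1`) gives 101000 nM, the higher of the two numbers. Compound 3 (`CC1(/C=C/c2ccc(O)cc2)C=CC(=O)O1`) differs from compound 2 by hydroxy in place of fluoro on an aromatic carbon. For the measured compounds named here, the only measured step that bears on this is a 3.0-fold higher number from compound 1 to compound 2 (0.47 log units; beyond the scatter), a modest one involving a different departing group. It suggests a step of similar or smaller size, and the data do not fix its direction. The expected change is a 1.4-fold lower number from compound 2 to compound 3 (0.16 log units; within the scatter), slightly toward a lower number. For compound 3 the estimate is 70000 nM, with an expected range from 25000 nM to 200000 nM.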

Compound 3, concentration for total growth inhibition: 143000 nM
Beside the measured number, compound 3's estimate is 2.0-fold (0.31 log units) below it, and the stated range covers the measured number.
By their numbers in this assay, from the lowest: compound 1; then compounds 2 and 3 (each within the scatter of the next).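

In this assay, hydroxy in place of fluoro on the aromatic carbon brings in a hydrogen-bond donor and acceptor, yet gives only a 1.4-fold higher number from compound 2 to compound 3 (0.15 log units; within the scatter) and so no separation at this position. Hydroxy in place of trifluoromethyl gives a 4.2-fold higher number from compound 1 to compound 3 (0.62 log units; beyond the scatter) and leaves compound 1 clear of both compound 2 and compound 3. Nothing shown here accounts for these differences. From the compounds shown here alone, whether an amine, a carboxylic acid or a methoxy group at this position would fall nearer compound 1 or nearer compound 2 and compound 3 stays open.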